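A few compounds are considered here, and "the series" means these few. Any claim that something is new, unique, unknown or untested is made for them only; others in the source may bear on it.

Compound 1 `CC(C)COc1cccc(-c2ccc(C(=O)N(Cc3cccc(OCCCCCC(=O)O)c3)C(C)C)cc2)c1` in an ADME assay on HepG2 cells (Homo sapiens) for cytotoxicity, read by CellTiter-Glo and resazurin assay, with a stated time of 72 h (on this read-out lower numbers stand for an effect already at smaller amounts and higher numbers for an effect only at larger amounts of compound), gives > 26000 nM, which is a limit of the assay rather than a number.
Compound 2 `CC(C)N(Cc1cccc(OCCCCCC(=O)O)c1)C(=O)c1ccc(-c2ccsc2)cc1` in this assay gives > 26000 nM, again a limit of the assay rather than a number.

Compound 2 therefore stands at the edge of what this assay can report: its toxicity toward the cells, if any, begins only at amounts beyond the highest tested. Within the data shown here, the one measured step, a step that the two limits leave unreadable from compound 1 to compound 2, cannot be given a size because of the limit of > 26000 nM in this assay, at which 2 of the 2 values shown sit, so it says only that exchanging one aromatic group for another at that position did not bring either compound into the readable range.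

Compound 3 `CC(C)N(Cc1cccc(OCCCCCC(=O)O)c1)C(=O)c1ccc(-c2ccc3cc[nH]c3c2)cc1` is reached from compound 2 by 1H-indol-6-yl in place of thiophen-3-yl on an aromatic carbon. Among the measured compounds shown here, no measured step covers this exchange, and the only comparison available ends in two limits, so there is nothing to suggest a move in either direction. The expectation is that compound 3 behaves like compound 2 and that a step that the limit leaves unreadable from compound 2 to compound 3 is a change no larger than the usual scatter. Compound 3 is estimated at 30000 nM, within a range from 10000 nM to 100000 nM, most likely reported again as a limit.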

Compound 3, half-maximal effective concentration: > 26000 nM
Compound 3 was reported as a limit; the forecaster's own chance of this, stated with the estimate: 75%; the middle value is on the limit's open side.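

Among these compounds, no step from compound 1 or compound 2 to compound 3 can be read, since all three compounds end at the same limit rather than at a number: the limit of > 26000 nM in this assay, at which 3 of the 3 values shown sit.

The compounds shown leave open at what amount, if any, each would begin to harm the cells, and whether exchanging these aromatic groups changes that amount at all.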